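This account rests on a few compounds, and the source may have more. Where it says the series, first, only, none or still open, it means among the compounds named here.

Compound 2 `COc1cc(-n2cnc3ccc(-c4ccc([N+](=O)[O-])cc4)cc32)cc(OC)c1OC` is one of three compounds built on a shared core; compound 1 `COc1cc(-n2cnc3ccc(-c4cc(F)ccc4F)cc32)cc(OC)c1OC` and compound 3 `COc1cc(-n2cnc3ccc(-c4cccc([N+](=O)[O-])c4)cc32)cc(OC)c1OC` differ from it only in the aryl group carried on that core. In a functional assay on A549 cells (Homo sapiens) for antiproliferative activity, read by MTT assay, with a stated time of 72 h (a lower number here means a stronger inhibitor, a higher number a weaker inhibitor), compound 2 gives 8940 nM, the highest of the three numbers, while compound 1 gives 7940 nM and compound 3 gives 5410 nM; a 1.1-fold higher number from compound 1 to compound 2 (0.05 log units; within the scatter), a 1.5-fold lower number from compound 1 to compound 3 (0.17 log units; within the scatter) and a 1.7-fold lower number from compound 2 to compound 3 (0.22 log units; within the scatter) all lie within the scatter. Compound 4 `COc1cc(-n2cnc3ccc(-c4ccc(O)cc4)cc32)cc(OC)c1OC` differs from compound 2 by hydroxy in place of nitro on an aromatic carbon. Among the measured compounds shown here, no measured step exchanges nitro for hydroxy, so the three small steps are the only guide, and they point to no step beyond the scatter in this assay. Compound 4 is therefore expected to give 7000 nM, between 2500 nM and 20000 nM. That estimate means a 1.3-fold lower number from compound 2 to compound 4 (0.11 log units; within the scatter), which is expected to stay within the scatter.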

Compound 4, half-maximal inhibitory concentration: 5090 nM
For compound 4 the middle estimate is 1.4-fold (0.14 log units) above the measured one; low and high end bracket the measured number.
By their numbers in this assay, from the lowest: compounds 4, 3, 1 and 2 (each within the scatter of the next).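

In this assay the exchange of nitro for hydroxy on this aromatic carbon, para to a large group, gives a 1.8-fold lower number from compound 2 to compound 4 (0.24 log units; within the scatter) and so shows that swapping a group with no hydrogen-bond donor for one with a hydrogen-bond donor leaves the number within the scatter here. The 4-hydroxyphenyl group also sits level with the other aryl groups, with a 1.1-fold lower number from compound 3 to compound 4 (0.03 log units; within the scatter) and a 1.6-fold lower number from compound 1 to compound 4 (0.19 log units; within the scatter) and so all four compounds remain within the scatter of one another. No evidence is shown that bears on this result. Going by these compounds, whether an amine or a carboxylic acid at this place would give a step beyond the scatter stays open.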